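The compounds below may be only part of what the source reports. "The series", "measured", "known", "first", "only" and "open" are said of these compounds alone.

The measured compounds are compound 1, `CN(Cc1cccc(F)c1)C(=O)CN(C)C(=O)c1ccc(S(C)(=O)=O)c([N+](=O)[O-])c1`, with > 60000 nM, and compound 2, `CN(Cc1ccccc1)C(=O)CNC(=O)c1ccc(S(C)(=O)=O)c([N+](=O)[O-])c1`, with > 60000 nM.

Compound 2 and compound 1 were tested in an assay on isolated protein for inhibition of vitamin D3 receptor (Homo sapiens), read by fluorescence polarization; on this read-out lower numbers stand for stronger inhibition and higher numbers for weaker inhibition. In this assay compound 1 reaches only a limit, > 60000 nM, and not a number. In this assay compound 2 likewise returns a limit, > 60000 nM, rather than a measured value. So compound 2 stands nowhere on a scale of numbers: it sits at the limit of > 60000 nM in this assay, at which 2 of the 2 values shown sit, together with compound 1, and no step between the two can be sized.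

Compound 3, `CN(Cc1cccc(F)c1)C(=O)CNC(=O)c1ccc(S(C)(=O)=O)c([N+](=O)[O-])c1`, has not yet been tested. It differs from compound 2 in one place: fluoro in place of hydrogen on an aromatic carbon, a fluoro in place of hydrogen on an aromatic carbon. Compound 1 carries the same 3-fluorobenzyl and still sits at the limit, so no change beyond the scatter is expected from compound 2 to compound 3, with the estimated step being a step that the limit leaves unreadable from compound 2 to compound 3. Compound 3 is therefore expected to give about 100000 nM in this assay, within a range of 30000 nM to 400000 nM, most likely reported again only as a limit.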

Compound 3, half-maximal inhibitory concentration: > 60000 nM
Compound 3: no number, only a limit (the forecaster's own chance of this, stated with the estimate: 90%); the middle value does not contradict the limit.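

In this assay compound 3 gives > 60000 nM as a limit and not a number. Going by these compounds alone, no step from compound 1 or compound 2 to compound 3 can be read, as all three stop at the same point: the limit of > 60000 nM in this assay, at which 3 of the 3 values shown sit.

The compounds shown leave open whether the fluoro or the methyl on the amide-type nitrogen changes inhibition at all, since none gives a number.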